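This account rests on a few compounds, and the source may have more. Where it says the series, first, only, none or still open, it means among the compounds named here.

Measured compounds in a functional assay on NUGC-3 cells (Homo sapiens) for cytotoxicity, read by sulforhodamine B assay, with a stated time of 72 h; a lower number here means a stronger inhibitor of growth, a higher number a weaker inhibitor of growth:

Compound 1, `O=C(Nc1cc(C(F)(F)F)cc(C(F)(F)F)c1)C1CCc2ccccc2N1C(=O)c1ccccc1Cl`, gives 1930 nM.
Compound 2, `CC(=O)N1c2ccccc2CCC1C(=O)Nc1cc(C(F)(F)F)cc(C(F)(F)F)c1`, gives only a limit of the assay, > 70000 nM.
Compound 3, `CCC(=O)N1c2ccccc2CCC1C(=O)Nc1cc(C(F)(F)F)cc(C(F)(F)F)c1`, gives 7220 nM.

All three share one core and differ only in the group on the carbonyl attached to the ring nitrogen. Among the two real numbers, compound 3 stands highest; the nearest is compound 1, and the step of a 3.7-fold higher number from compound 1 to compound 3 (0.57 log units; beyond the scatter) is modest. Compound 2 reaches (the limit of > 70000 nM in this assay, at which 1 of the 3 values shown sits). The step of an at least 9.6-fold lower number from compound 2 to compound 3 (0.98 log units; beyond the scatter) shows that a longer acyl chain gives a lower number. Compound 4, `O=C(Nc1cc(C(F)(F)F)cc(C(F)(F)F)c1)C1CCc2ccccc2N1`, carries no acyl group at all: hydrogen in place of propanoyl on a nitrogen on an aromatic ring in a ring. Among the compounds with values here, no measured step removes the acyl group entirely, but both measured changes show that a smaller group on this carbonyl raises the number, in one case beyond the limit. A further step in the same direction is therefore expected to raise the number again, possibly past what this assay can report. Compound 4 is expected to give about 60000 nM, between 15000 nM and 250000 nM. The expected step is an 8.3-fold higher number from compound 3 to compound 4 (0.92 log units; beyond the scatter).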

Compound 4, concentration for 50% growth inhibition: 8760 nM
Beside the measured number, compound 4's estimate is 6.8-fold (0.84 log units) above it, and the stated range ends above it.
By their numbers in this assay, from the lowest: compound 1; then compounds 3 and 4 (each within the scatter of the next). At a limit, above all of these: compound 2.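

In this assay, taking the acyl group off entirely does not extend the rise seen on shortening it, and compound 4 goes against that pattern: a 1.2-fold higher number from compound 3 to compound 4 (0.08 log units; within the scatter), so a propanoyl group and a bare hydrogen on this ring nitrogen cannot be told apart here. Within the data shown here, the acyl groups therefore do not act alike when set against hydrogen, with an at least 7.9-fold lower number from compound 2 to compound 4 (0.90 log units; beyond the scatter) for acetyl and a 4.5-fold higher number from compound 1 to compound 4 (0.66 log units; beyond the scatter) for (2-chlorophenyl)carbonyl, the only group here that gives a lower number than hydrogen. Compound 2 remains a limit, not a number: the limit of > 70000 nM in this assay, at which 1 of the 4 values shown sits.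

Still open, going by these compounds, is whether the lower number of compound 1 depends on its chlorine, which a plain benzoyl group would test. Also open, on these data alone, is what a longer chain such as butanoyl, or a methyl placed directly on this nitrogen, would give.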